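Swapping (methylsulfonyl)methyl for (benzylsulfonyl)oxy on the shared core

This account rests on a few compounds, and the source may have more. Where it says the series, first, only, none or still open, it means among the compounds named here.

Measured in a functional assay on A-375 cells (Homo sapiens) for cytotoxicity, read by MTT assay; on this read-out higher numbers stand for weaker inhibition and lower numbers for stronger inhibition:
Compound 1 `C#CCOc1cc(/C=C/C(=O)c2ccc(OC)c3c2OC(C)(C)C=C3)ccc1OC`: > 10000 nM, a limit
Compound 2 `COc1ccc(/C=C/C(=O)c2ccc(OC)c3c2OC(C)(C)C=C3)cc1OC(=O)c1ccc(Br)cc1`: 420 nM
Compound 3 `COc1ccc(/C=C/C(=O)c2ccc(OC)c3c2OC(C)(C)C=C3)cc1CS(C)(=O)=O`: > 10000 nM, a limit

Compound 3 stands at the limit of > 10000 nM in this assay, at which 2 of the 3 values shown sit. Compound 4 `COc1ccc(/C=C/C(=O)c2ccc(OC)c3c2OC(C)(C)C=C3)cc1OS(=O)(=O)Cc1ccccc1` differs from it as follows: (benzylsulfonyl)oxy in place of (methylsulfonyl)methyl on an aromatic carbon. Among the measured compounds shown here, two measured steps bear on this change: an at least 23-fold lower number from compound 1 to compound 2 (1.37 log units; beyond the scatter) and an at least 23-fold higher number from compound 2 to compound 3 (1.37 log units; beyond the scatter). For the measured compounds named here, both turn on ((4-bromophenyl)carbonyl)oxy, the only group of the three with an aromatic ring. As far as these compounds go, compound 4 also gains such a ring, although its sulfonyl link is untested here, so a large drop is expected, though less surely than those steps alone suggest. The expected change is an at least 6.6-fold lower number from compound 3 to compound 4 (0.82 log units; beyond the scatter) in this assay. For compound 4 the estimate is 1500 nM, with an expected range of 300 nM to 8000 nM.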

Compound 4, half-maximal inhibitory concentration: > 10000 nM
Compound 4 gave a limit, no number; the forecaster's own chance of this, stated with the estimate: 25%; at least 6.6-fold (0.82 log units) between middle value and limit.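

In this assay, benzylsulfonyl in place of (4-bromophenyl)carbonyl on the oxygen gives an at least 23-fold higher number from compound 2 to compound 4 (1.37 log units; beyond the scatter). An aromatic ring in the group at this position is therefore not enough for a readable number, and compound 2 remains the only one of the four that has one. Compound 4 gives only a limit: the limit of > 10000 nM in this assay, at which 3 of the 4 values shown sit.

As far as these compounds go, the steps to compound 4 from compound 3 and compound 1 cannot be read, so how far these three lie apart stays open. Also open, from the compounds shown here alone, is whether the bromine or the carbonyl matters, which an unsubstituted benzoyl group or an amide link could test.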